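Swapping a Phenoxy for a Methylamino Group

The compounds below may be only part of what the source reports. "The series", "measured", "known", "first", "only" and "open" are said of these compounds alone.

Measured so far:
Compound 1 `COc1ccc(-c2ccn(CCC(C)C)c(=O)c2C#N)cc1Cl`: 363 nM
Compound 2 `CC(C)CCn1ccc(-c2ccc(OC3CCCC3)c(Cl)c2)c(C#N)c1=O`: 100 nM
Compound 3 `CC(C)CCn1ccc(-c2ccc(Oc3ccccc3)cc2)c(C#N)c1=O`: 42 nM

In a functional assay on CHO cells for positive allosteric modulation of metabotropic glutamate receptor 2 (Homo sapiens), read by scintillation counting and GTPgammaS binding, with a stated time of 30 min (a higher number here means that more compound is needed for the effect, a lower number that less compound is needed), compound 3 gives the lowest number of the three. Its nearest neighbour is compound 2, which gives 100 nM, a gap beyond the scatter; compound 1 stands furthest away with 363 nM, also beyond the scatter. For the measured compounds named here, only one pair among the measured compounds differs in a single place: the change a 3.6-fold lower number from compound 1 to compound 2 (0.56 log units; beyond the scatter), where cyclopentyl replaced methyl on an oxygen attached to the aromatic ring and the number fell by a modest amount.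

Compound 4 `CNc1ccc(-c2ccn(CCC(C)C)c(=O)c2C#N)cc1` has not yet been measured. It differs from compound 3 in one place: methylamino in place of phenoxy on an aromatic carbon. The group that leaves is the largest of the three oxygen-borne groups seen so far; the group that enters is the smallest of any at that place. Across compounds 1, 2 and 3 the larger the group at this position, the lower the number, with the measured step from compound 1 to compound 2 pointing the same way, so a return to a small group is expected to raise the number again. For compound 4 the expected change is therefore a 9.5-fold higher number from compound 3 to compound 4 (0.98 log units; beyond the scatter), landing near where compound 1 stands. The estimate for compound 4 in this assay is 400 nM, with a likely range from 120 nM to 1500 nM.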

Compound 4, half-maximal effective concentration: 460 nM
The estimate for compound 4 lay 1.2-fold (0.06 log units) below the measured number; the measured number falls inside the stated range.
By their numbers in this assay, from the lowest: compound 3; then compound 2; then compounds 1 and 4 (each within the scatter of the next).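

In this assay, for the compounds shown here, the change from phenoxy to methylamino gives an 11-fold higher number from compound 3 to compound 4 (1.04 log units; beyond the scatter), a large step and the first single change here that removes an aromatic ring from this place. It points the same way as a 3.6-fold lower number from compound 1 to compound 2 (0.56 log units; beyond the scatter), where the larger cyclopentyl group gave the lower number, but that modest step kept the oxygen and sat on a ring that also carries a chlorine, so the number now responds to this place on two different backgrounds. The new step swaps several things at once, including the ring, the atom attached to the aromatic carbon and the added hydrogen-bond donor, and no measurement available here explains why the number rose.

Which of these swapped features accounts for the rise stays open. A phenylamino group, which keeps the aromatic ring while bringing in the nitrogen and its hydrogen, and a methoxy group on the chlorine-free ring of compound 3, which keeps the oxygen while losing the ring, would help separate them.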